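Two sulfur side chains and a third to come

The compounds below may be only part of what the source reports. "The series", "measured", "known", "first", "only" and "open" are said of these compounds alone.

- Compound 1 `Cc1cc(Nc2cc(-c3ccccc3)[nH]n2)n2nc(SCCCc3ccccc3)nc2n1`: 40200 nM
- Compound 2 `C=CCSc1nc2nc(C)cc(Nc3cc(-c4ccccc4)[nH]n3)n2n1`: > 50000 nM (a limit)

Both compounds were tested in an ADME assay on GES1 cells (Homo sapiens) for inhibition, read by MTT assay, with a stated time of 72 h; on this read-out higher numbers stand for weaker inhibition and lower numbers for stronger inhibition. Compound 2 gives > 50000 nM, which is a limit of the assay and not a number. From the compounds shown here alone, it therefore stands at the limit of > 50000 nM in this assay, at which 1 of the 2 values shown sits, and its true position is unknown.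

The next compound, compound 3 `Cc1cc(Nc2cc(-c3ccccc3)[nH]n2)n2nc(SCc3nc4ccccc4[nH]3)nc2n1`, keeps the shared core and changes only the side chain on sulfur: 1H-benzimidazol-2-yl in place of vinyl on a saturated chain carbon bound to a sulfur. In words, 1H-benzimidazol-2-yl replaces vinyl on a saturated chain carbon bound to a sulfur.

Among the measured compounds shown here, only one measured step bears on this change, and it concerns the same place: an at least 1.2-fold higher number from compound 1 to compound 2 (0.09 log units; that floor lies within the scatter). Compound 1, which carries phenethyl there, gives 40200 nM, so a large group with an aromatic ring has been seen at this place without a strong value. On that single comparison, only a small move towards lower numbers is expected, possibly none beyond the scatter, and another limit is quite possible.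

The expected step is an at least 1.2-fold lower number from compound 2 to compound 3 (0.09 log units; that floor lies within the scatter). The estimate for compound 3 is 40000 nM, with an expected range from 15000 nM to 70000 nM.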

Compound 3, half-maximal inhibitory concentration: 27800 nM
Compound 3: middle estimate off by 1.4-fold (0.16 log units), on the high side; the measured number falls inside the stated range.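

In this assay, compound 3 shows that a 1H-benzimidazol-2-yl group on the saturated chain carbon bound to a sulfur gives a readable number, and exchanging the phenethyl of compound 1 for it gives a 1.4-fold lower number from compound 1 to compound 3 (0.16 log units; within the scatter), so these two quite different ring-bearing groups cannot be told apart here. Set against the vinyl of the allyl side chain, the same group gives an at least 1.7-fold lower number from compound 2 to compound 3 (0.25 log units; that floor lies within the scatter), which is only a floor and does not establish a real move. Compound 2 holds a limit of the assay and not a number, so its true distance from compound 3 stays unknown: the limit of > 50000 nM in this assay, at which 1 of the 3 values shown sits.

Still open, from the compounds shown here alone, is whether any group at this place can move the number beyond the scatter, for instance an amine or a carboxylic acid at the end of the chain. Also open is whether a plain benzyl group, with carbon-only rings in place of the nitrogen-bearing one, would read differently from 1H-benzimidazol-2-yl, and the compounds shown say nothing about changes to the shared core.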